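This account rests on a few compounds, and the source may have more. Where it says the series, first, only, none or still open, it means among the compounds named here.

Compound 1 is `Cc1ccc(C(=O)Nc2ccc(-c3ccccc3)cn2)cc1` and compound 2 is `CC(C)Oc1ccc(C(=O)Nc2ccc(-c3ccccc3)cn2)cc1`; the two share one core and differ only in the group carried on an aromatic carbon. In an assay on isolated protein (Aquatica lateralis) for inhibition of Luciferin 4-monooxygenase (Luciola lateralis), read by a luciferase reporter, tested at 10 uM (on this read-out higher numbers stand for more inhibition at the one concentration tested (going by the name of the read-out) and lower numbers for less inhibition), compound 1 gives 18%, and compound 2 gives 12%. Within the data shown here, compound 2 stands lowest of the two numbers measured so far, its nearest neighbour being compound 1, and the gap between them lies within the scatter, so no order between the two can be claimed.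

Compound 3 is `CN(C)c1ccc(C(=O)Nc2ccc(-c3ccccc3)cn2)cc1`. It differs from compound 2 in one place: dimethylamino in place of isopropoxy on an aromatic carbon. Among the measured compounds shown here, no measured step exchanges a dimethylamino group for another, so the only step that bears on this one is a number 6 percentage points lower from compound 1 to compound 2 (within the scatter), an exchange of two groups at the same place that did not move the read-out beyond the scatter. With no further information, the step expected for compound 3 is a number 2 percentage points higher from compound 2 to compound 3 (within the scatter), none beyond the scatter. Compound 3 is estimated at 14%, with a range from 2% to 28%.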

Compound 3, a percentage reported as inhibition, at one concentration (the size of the read-out at that concentration, not a potency): 35%
For compound 3 the middle estimate is 21 percentage points below the measured one; measured number outside the range, above it.
By their numbers in this assay, from the lowest: compounds 2 and 1 (each within the scatter of the next); then compound 3.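

In this assay the group on this aromatic carbon, para to a large group, can move the read-out beyond the scatter: dimethylamino in place of isopropoxy gives a number 23 percentage points higher from compound 2 to compound 3 (beyond the scatter) and dimethylamino in place of methyl gives a number 17 percentage points higher from compound 1 to compound 3 (beyond the scatter) in the same direction. The position is therefore not indifferent to its substituent, as the earlier exchange of methyl and isopropoxy alone could not show, and among these three groups only dimethylamino stands apart. Isopropoxy and dimethylamino match in ring count, hydrogen-bond donors, hydrogen-bond acceptors and net charge, so these counts do not separate them, and no available measurement explains the difference.

Open, from the compounds shown here alone, is whether the higher number belongs to dimethylamino itself or extends to other nitrogen groups at this place, such as an unsubstituted amine, a methylamino group or a pyrrolidine. Also open, going by these compounds, is whether a larger dialkylamine such as diethylamino, or a charged group such as a carboxylic acid, would hold, raise or lower the read-out on the shared core.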